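The compounds below may be only part of what the source reports. "The series", "measured", "known", "first", "only" and "open" are said of these compounds alone.

The three measured compounds are compound 1 `N=C(N)N/N=C/c1c(-c2cccs2)nc2sccn12`, compound 2 `Cc1cc(-c2nc3sccn3c2/C=N/NC(=N)N)c(C)s1` and compound 3 `Cc1cc(-c2nc3n(c2/C=N/NC(=N)N)CCS3)c(C)s1`. In a functional assay on cells (Cancer cell lines, Homo sapiens) for inhibition (a higher number here means a weaker inhibitor of growth, a lower number a stronger inhibitor of growth), compound 1 gives 24000 nM, compound 2 gives 32400 nM and compound 3 gives 29500 nM; all three values lie within the scatter of one another. Compound 2 and compound 1 differ by thiophen-2-yl in place of 2,5-dimethylthiophen-3-yl on an aromatic carbon, and the step of a 1.4-fold lower number from compound 2 to compound 1 (0.13 log units; within the scatter). The difference between the core of compound 2 and the core of compound 3 is not broken down here. Compound 4 `N=C(N)N/N=C/c1c(-c2cccs2)nc2n1CCS2` is not yet measured; it differs from compound 3 by thiophen-2-yl in place of 2,5-dimethylthiophen-3-yl on an aromatic carbon, the same kind of change as between compound 2 and compound 1, though around the place it is also two ring bonds from two ring atoms that each bear a fused ring. Because the earlier step of a 1.4-fold lower number from compound 2 to compound 1 (0.13 log units; within the scatter) stayed within the scatter, the step from compound 3 to compound 4 is expected to be small, a 1.3-fold lower number from compound 3 to compound 4 (0.13 log units; within the scatter). Compound 4 is estimated to give 22000 nM in this assay, between 11000 nM and 45000 nM.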

Compound 4, concentration for total growth inhibition: 38900 nM
The estimate for compound 4 lay 1.8-fold (0.25 log units) below the measured number, within the range that was stated.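

In this assay, placing thiophen-2-yl where 2,5-dimethylthiophen-3-yl stood gives a 1.3-fold higher number from compound 3 to compound 4 (0.12 log units; within the scatter) and so stays within the scatter on this second core as well. Set side by side, the two cores show no difference in how they take this change: the same change on two cores in this assay, a 1.4-fold lower number (0.13 log units; within the scatter) from compound 2 to compound 1 and a 1.3-fold higher number (0.12 log units; within the scatter) from compound 3 to compound 4, 1.8-fold (0.25 log units) apart, within the scatter of two such steps. This shows that the small size of the step carries across these two cores, but it gives the step no direction and does not show that it would stay small on any other core.

The compounds shown leave open whether a phenyl ring, an amine or a carboxylic acid in place of the thiophene would move the number beyond the scatter. Also open, on these data alone, is what a longer chain would do in place of the group of 6 heavy atoms.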